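This account rests on a few compounds, and the source may have more. Where it says the series, first, only, none or still open, it means among the compounds named here.

Compound 2 `O=COC1(C(=O)Nc2ccc([N+](=O)[O-])cc2)CCCCC1` stands at the lowest of the two numbers recorded so far in a functional assay on NFS-60 cells (Mus musculus) for inhibition, read by MTT assay, with a stated time of 72 h (on this read-out lower numbers stand for stronger inhibition and higher numbers for weaker inhibition), where compound 2 gives 33.8 nM. Going by the values given here, its only neighbour is compound 1 `COc1ccc(C(=O)OC2(C(=O)Nc3ccc([N+](=O)[O-])cc3)CCCCC2)cc1`, which in this assay gives 38.8 nM; the step of a 1.1-fold lower number from compound 1 to compound 2 (0.06 log units; within the scatter) lies within the scatter. Compound 3 `CC(=O)Oc1ccccc1C(=O)OC1(C(=O)Nc2ccc([N+](=O)[O-])cc2)CCCCC1` differs from compound 2 by 2-acetoxyphenyl in place of hydrogen on a carbonyl carbon. Among the compounds with values here, the one measured step that bears on this place, the removal of 4-methoxyphenyl from compound 1 to compound 2, changed nothing beyond the scatter, so for compound 3 a step of a 1.2-fold higher number from compound 2 to compound 3 (0.07 log units; within the scatter) is expected, with no change beyond the scatter. Compound 3 is therefore estimated at 40 nM, between 18 nM and 90 nM.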

Compound 3, half-maximal inhibitory concentration: 11.3 nM
The estimate for compound 3 lay 3.5-fold (0.55 log units) above the measured number; measured number outside the range, below it.
By their numbers in this assay, from the lowest: compound 3; then compounds 2 and 1 (each within the scatter of the next).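

In this assay, this place on the carbonyl carbon proves sensitive to what it carries: 2-acetoxyphenyl gives a 3.0-fold lower number from compound 2 to compound 3 (0.48 log units; beyond the scatter) and, set against 4-methoxyphenyl, a 3.4-fold lower number from compound 1 to compound 3 (0.54 log units; beyond the scatter) as well. Compound 1 and compound 3 both carry a six-membered aromatic ring here, so the ring alone does not set the number; what is attached to it differs. No measured evidence explains this difference. On these data alone, it remains open whether the acetoxy part of the group is needed, and how a plain phenyl, an amine or a carboxylic acid would behave at this place.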